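The source may hold more compounds than are shown below. What is called first, only, known or untested is meant among the compounds shown, and "the series" means these compounds.

Measured compounds in the series:

Compound 1, `COc1cc(-c2cc(/C=C/C(=O)c3ccc(N)cc3)[nH]n2)cc(OC)c1OC` — in a functional assay on NCI-H522 cells (Homo sapiens) for inhibition, read by sulforhodamine B assay, with a stated time of 48 h (a higher number here means that more compound is tolerated, a lower number that less compound is tolerated), compound 1 gives 9810 nM.
Compound 2, `COc1ccc(-c2cc(/C=C/C(=O)c3ccc(OC)c(OC)c3)[nH]n2)cc1` — in this assay compound 2 gives 5910 nM.
Compound 3, `COc1cc(-c2cc(/C=C/C(=O)c3ccc(Cl)c(Cl)c3)[nH]n2)cc(OC)c1OC` — in this assay compound 3 gives 6970 nM.

Compound 1 has the highest of the three numbers, but neither gap separates it from the others: the step of a 1.4-fold lower number from compound 1 to compound 3 (0.15 log units; within the scatter) lies within the scatter, and the gap to compound 2 is likewise within the scatter. On these numbers the three compounds are indistinguishable.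

The compound to be measured is compound 4, `COc1ccc(-c2cc(/C=C/C(=O)c3ccc(N)cc3)[nH]n2)cc1OC`. It differs from compound 1 by hydrogen in place of methoxy on an aromatic carbon.

Among the compounds with values here, no measured step bears directly on this change. Within the data shown here, the single step in hand, from compound 1 to compound 3, concerns the group on the carbonyl carbon and was within the scatter. Compound 2 carries a different pattern on the ring attached to the shared core, but its partner on the carbonyl carbon also differs, so its value gives no isolated reading of the present change. Among the measured compounds shown here, with no precedent, and with the three measured values all within the scatter of one another, no step beyond the scatter is expected for this assay in either direction.

Compound 4 is therefore expected to give about 9000 nM in this assay, in the range 4000 nM to 22000 nM. The expected step of a 1.1-fold lower number from compound 1 to compound 4 (0.04 log units; within the scatter) is estimated to stay within the scatter.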

Compound 4, concentration lethal to 50% of the cells: 6300 nM
Compound 4: middle estimate off by 1.4-fold (0.15 log units), on the high side; measured number inside the range.
By their numbers in this assay, from the lowest: compounds 2, 4, 3 and 1 (each within the scatter of the next).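

Compound 1 and compound 4 form the only pair shown that isolates hydrogen in place of methoxy on an aromatic carbon, ortho to a methoxy group and meta to a large group, with 4-aminophenyl held on the carbonyl carbon. In this assay this change gives a 1.6-fold lower number from compound 1 to compound 4 (0.19 log units; within the scatter), so at this position the read-out does not separate hydrogen from methoxy, and the earlier step, which concerned only the group on the carbonyl carbon, could not show this. The data shown offer no measurement that accounts for this result.

As far as these compounds go, it remains open whether another group at this position, such as an amine, a carboxylic acid or a longer chain like butoxy, would produce a step beyond the scatter. From the compounds shown here alone, it also remains open whether hydrogen in place of methoxy reads the same when 3,4-dichlorophenyl stands on the carbonyl carbon instead of 4-aminophenyl.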